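This account rests on a few compounds, and the source may have more. Where it says the series, first, only, none or still open, it means among the compounds named here.

Measured so far in a functional assay on HCT-116 cells (Homo sapiens) for antiproliferative activity, read by CCK-8 assay, with a stated time of 72 h, tested at 8 uM; a lower number here means a weaker effect, a higher number a stronger effect of the compound at the concentration tested:
compound 1 `CCCCn1cnc2c(Nc3cccc(Cl)c3)nc(NCOCc3ccc(/C=C/C(=O)Nc4ccccc4N)cc3)nc21`: 10.9%
compound 2 `Nc1ccccc1NC(=O)/C=C/c1ccc(Cn2cnc3c(Nc4cccc(Cl)c4)nc(Cl)nc32)cc1`: 15.8%

Compound 1 gives the lower of the two numbers, but the gap to compound 2 lies within the scatter, so the two values show no order. Going by the values given here, no step between measured compounds differing in one place is available. Compound 3 `Nc1ccccc1NC(=O)/C=C/c1ccc(COCNc2nc(Nc3cccc(Cl)c3)c3ncn(C4CCCC4)c3n2)cc1` differs from compound 1 by cyclopentyl in place of butyl on an aromatic nitrogen. Among the compounds with values here, with no measured step on this change, the step of a number 2.1 percentage points higher from compound 1 to compound 3 (within the scatter) is expected to stay within the scatter, in no particular direction. Compound 3 is expected to give 13% in this assay, between 3% and 25%.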

Compound 3, a percentage reported as inhibition, at one concentration (the size of the read-out at that concentration, not a potency): 9.19%
Beside the measured number, compound 3's estimate is 3.8 percentage points above it, within the range that was stated.
By their numbers in this assay, from the lowest: compounds 3, 1 and 2 (each within the scatter of the next).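

Going by these compounds alone, the first one-place comparison, read in this assay, replaces butyl with cyclopentyl on the aromatic nitrogen and gives a number 1.7 percentage points lower from compound 1 to compound 3 (within the scatter) as the step. At this position, closing the carbon chain into a five-membered ring therefore leaves the read-out unresolved at the one concentration tested, and the comparison gives no direction for this change. No available measurement explains this result.

As far as these compounds go, it remains open whether an amine, a carboxylic acid or a longer chain on this aromatic nitrogen would shift the inhibition beyond the scatter.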